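Aryl versus cycloalkyl on the piperazine nitrogen of an aminothiophene

This account rests on a few compounds, and the source may have more. Where it says the series, first, only, none or still open, it means among the compounds named here.

Measured so far:
compound 1, `Nc1scc(CN2CCN(c3cc(Cl)cc(Cl)c3)CC2)c1C(=O)c1ccc(Cl)cc1`, gives -74%
compound 2, `Nc1scc(CN2CCC(c3ccc(Cl)cc3)CC2)c1C(=O)c1ccc(Cl)cc1`, gives -61%
compound 3, `Nc1scc(CN2CCN(C3CCCCCC3)CC2)c1C(=O)c1ccc(Cl)cc1`, gives -25%

These three compounds were compared in a functional assay on CHO cells with adenosine receptor A1 (Homo sapiens) as the target, read by cAMP accumulation and immunoassay, with a stated time of 6 min, tested at 10 uM; a lower number here means a stronger effect, a higher number a weaker effect of the compound at the concentration tested. Compound 3 stands highest of the three numbers, that is, it shows the weakest effect at the concentration tested. Its nearest neighbour is compound 2, whose number is lower by an amount beyond the scatter, and furthest from it is compound 1.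

For the measured compounds named here, one measured step bears directly on the next change. From compound 1 to compound 3 the number changed by a number 49 percentage points higher from compound 1 to compound 3 (beyond the scatter), a large step, when cycloheptyl took the place of 3,5-dichlorophenyl on the amine nitrogen in the ring.

Compound 4, `Nc1scc(CN2CCN(c3cccc(Cl)c3)CC2)c1C(=O)c1ccc(Cl)cc1`, reverses the sense of that exchange: 3-chlorophenyl in place of cycloheptyl on an amine nitrogen in a ring. Going by the values given here, since the one measured step in this direction was large, a large step back toward a lower number is expected for compound 4, although the entering group carries a single chlorine where compound 1 carries two, so the full return is not assured.

The expected step is a number 35 percentage points lower from compound 3 to compound 4 (beyond the scatter). For compound 4 in this assay the estimate is -60%, with a range from -80% to -35%.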

Compound 4, a percentage reported as activity, at one concentration (the size of the read-out at that concentration, not a potency): -77%
Estimate against measurement, compound 4: 17 percentage points above, and the stated range covers the measured number.
By their numbers in this assay, from the lowest: compounds 4 and 1 (each within the scatter of the next); then compound 2; then compound 3.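

In this assay, the exchange between a cycloalkyl and an aryl group on this amine nitrogen in a ring now reads in both directions: 3-chlorophenyl in place of cycloheptyl gave a number 52 percentage points lower from compound 3 to compound 4 (beyond the scatter), so the large step is not confined to the 3,5-dichlorophenyl group. For the compounds shown here, the result also isolates the second chlorine for the first time: hydrogen in place of chloro on an aromatic carbon gave a number 3 percentage points lower from compound 1 to compound 4 (within the scatter), so the two aryl compounds cannot be told apart in this read-out, and a single chloro on the phenyl ring serves as well here as two. No evidence is available to explain why the aryl groups and cycloheptyl part so widely in this assay.

The compounds shown leave open whether any chlorine is needed at all, since a plain phenyl group, a methoxyphenyl group or a pyridine ring on the same nitrogen could sit anywhere in this range. Each number also describes the size of the effect at a single concentration, so the compounds that cannot be separated here may still differ in potency.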